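Amine swap on the triazole arm of compound 3

A few compounds are considered here, and "the series" means these few. Any claim that something is new, unique, unknown or untested is made for them only; others in the source may bear on it.

In an assay for inhibition of Nicotinamide phosphoribosyltransferase (Mus musculus), read by fluorescence, with a stated time of 1 h, in the presence of a further agent that is not named here (on this read-out higher numbers stand for weaker inhibition and lower numbers for stronger inhibition), compound 3 `CN(C)Cc1cn(-c2ccccc2C(=O)NCCCCCCCn2cc(-c3cccnc3)nn2)nn1` gives 42.4 nM, which places it second highest of the three numbers measured. Compound 2 `O=C(NCCCCCCCn1cc(-c2cccnc2)nn1)c1ccccc1-c1cccnc1` gives 28.5 nM, and the step of a 1.5-fold higher number from compound 2 to compound 3 (0.17 log units; within the scatter) is within the scatter. Compound 1 `NC(=O)c1ccccc1-c1ccccc1C(=O)NCCCCCCCn1cc(-c2cccnc2)nn1` gives 87.9 nM, and the step of a 2.1-fold lower number from compound 1 to compound 3 (0.32 log units; beyond the scatter) is modest, as is a 3.1-fold lower number from compound 1 to compound 2 (0.49 log units; beyond the scatter). Compound 4 `CC(C)N1CCN(Cc2cn(-c3ccccc3C(=O)NCCCCCCCn3cc(-c4cccnc4)nn3)nn2)CC1` differs from compound 3 by 4-isopropylpiperazin-1-yl in place of dimethylamino on a saturated chain carbon bound to an aromatic carbon. Going by the values given here, none of the measured steps touches this part of the molecule: all three alter the group on the shared core, not the amine on the methyl of the triazole. Among the compounds with values here, the only guidance is that compound 3, carrying the dimethylamino group, sits close to compound 2 in this assay, so this arm tolerates change. Within the data shown here, with no step that bears directly on the amine, the expectation is no change beyond the scatter, so the estimated step is a 1.1-fold higher number from compound 3 to compound 4 (0.03 log units; within the scatter). Compound 4 is therefore expected to give about 45 nM, within a range from 18 nM to 110 nM.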

Compound 4, half-maximal inhibitory concentration: 24.7 nM
Beside the measured number, compound 4's estimate is 1.8-fold (0.26 log units) above it; the measured number falls inside the stated range.
By their numbers in this assay, from the lowest: compounds 4, 2 and 3 (each within the scatter of the next); then compound 1.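

Going by these compounds alone, the earlier steps all changed the group on the shared core, so this is the first look at the amine itself. In this assay, exchanging dimethylamino for 4-isopropylpiperazin-1-yl gives a 1.7-fold lower number from compound 3 to compound 4 (0.23 log units; within the scatter). The position on a saturated chain carbon bound to an aromatic carbon therefore accepts a group growing from 3 heavy atoms to 9 and gaining a six-membered non-aromatic ring, with no change beyond the scatter. No measurement shown here accounts for this result.

This single swap changes the ring and the isopropyl group together, so a plain piperazin-1-yl or a 4-methylpiperazin-1-yl group would be needed to separate them. As far as these compounds go, it also remains open whether a non-amine group, such as a carboxylic acid on the same carbon, would be accepted equally well.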